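The source may hold more compounds than are shown below. What is called first, only, known or untested is meant among the compounds shown, and "the series" means these compounds.

Compound 1 `Cc1ccccc1Nc1nc(Nc2ccc(N3CCN(C(=O)OC(C)(C)C)CC3)cc2)ncc1Cl` in a functional assay on Jurkat cells (Homo sapiens) for inhibition, read by CCK-8 assay, with a stated time of 48 h (a lower number here means a stronger inhibitor of growth, a higher number a weaker inhibitor of growth), gives 5120 nM. Compound 2 `CN1CCN(c2ccc(Nc3ncc(Cl)c(Nc4ccccc4)n3)nc2)CC1` reaches only the limit of this assay, > 100000 nM, so no number is known for it, as the limit of > 100000 nM in this assay, at which 1 of the 2 values shown sits, records. Compound 3 `Cc1cc(C)c(Nc2nc(Nc3ccc(N4CCN(C)CC4)cn3)ncc2Cl)c(C)c1` differs from compound 2 by 2,4,6-trimethylphenyl in place of phenyl on a nitrogen on an aromatic ring. Among the measured compounds shown here, no measured pair isolates this change; compound 1 also carries methyl on its anilino ring but differs from compound 2 elsewhere as well, so its value is only a loose pointer. The expected step in this assay, an at least 3.3-fold lower number from compound 2 to compound 3 (0.52 log units; beyond the scatter), is toward stronger inhibition, beyond the scatter. Compound 3 is estimated at 30000 nM, between 5000 nM and 150000 nM.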

Compound 3, concentration for 50% growth inhibition: 7600 nM
Compound 3: the middle estimate sits 3.9-fold (0.60 log units) above what was measured, and the stated range covers the measured number.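

In this assay, 2,4,6-trimethylphenyl in place of phenyl on a nitrogen on an aromatic ring gives an at least 13-fold lower number from compound 2 to compound 3 (1.11 log units; beyond the scatter). Among the compounds shown here, this is the first single-place change read, and it shows that the group on this nitrogen can shift growth inhibition by a large step. Compound 2 carries no number, only a limit, so the step is bounded on one side alone: the limit of > 100000 nM in this assay, at which 1 of the 3 values shown sits.

Which of the three methyl groups carries the step remains open. So does whether methoxy or fluorine on the same ring would give a comparable step.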